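The compounds below may be only part of what the source reports. "The series", "measured", "known", "first", "only" and "open" are said of these compounds alone.

Measured so far:
- Compound 1, `CSc1ccc(CSc2nc(-c3ccc(Br)cc3)c(-c3ccncc3)[nH]2)cc1`, gives 2400 nM in a functional assay (Homo sapiens) for inhibition; on this read-out lower numbers stand for stronger inhibition and higher numbers for weaker inhibition.
- Compound 2, `C[S+]([O-])c1ccc(CSc2nc(-c3ccc(Br)cc3)c(-c3ccncc3)[nH]2)cc1`, gives 820 nM in this assay.
- Compound 3, `CSc1cc(Cl)cc(CSc2nc(-c3ccc(F)cc3)c(-c3ccncc3)[nH]2)c1O`, gives 640 nM in this assay.

Compound 1 and compound 2 share one core and differ in a single place: a group of 3 heavy atoms (1 carbon, 1 oxygen, 1 sulfur; no ring) in place of a group of 2 heavy atoms (1 carbon, 1 sulfur; no ring), on an aromatic carbon. That change gave a 2.9-fold lower number from compound 1 to compound 2 (0.47 log units; beyond the scatter). Compound 3 carries a different core; how it differs from compound 1 is not broken down here. Its number is within the scatter of that of compound 2, so nothing can be said about which of the two is stronger; against compound 1 it stands a good deal lower.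

Compound 4, `C[S+]([O-])c1cc(Cl)cc(CSc2nc(-c3ccc(F)cc3)c(-c3ccncc3)[nH]2)c1O`, has not been measured. It differs from compound 3 in the same way that compound 2 differs from compound 1: a group of 3 heavy atoms (1 carbon, 1 oxygen, 1 sulfur; no ring) in place of a group of 2 heavy atoms (1 carbon, 1 sulfur; no ring), on an aromatic carbon. The surroundings are not identical, though. In compound 1 the group sits para to a large group; in compound 3 it sits ortho to a hydroxy group, meta to a chloro group and meta to a large group. It is therefore the same kind of change, not the same change.

Going by the values given here, with only one measured example of this step, the expectation for compound 4 rests on compound 1 and compound 2 alone, since a 2.9-fold lower number from compound 1 to compound 2 (0.47 log units; beyond the scatter) is the sole guide. On that basis a step of about a 2.5-fold lower number from compound 3 to compound 4 (0.39 log units; beyond the scatter) is expected from compound 3 to compound 4, with wider uncertainty because the surroundings differ. Compound 4 is accordingly estimated at 260 nM, plausibly between 100 nM and 700 nM.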

Compound 4, half-maximal inhibitory concentration: 4400 nM
Compound 4: the middle estimate sits 17-fold (1.23 log units) below what was measured; the whole stated range lies below it.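

In this assay the replacement of methylsulfanyl by its oxygen-carrying counterpart gave a 6.9-fold higher number from compound 3 to compound 4 (0.84 log units; beyond the scatter) and so ran the opposite way to the earlier pair, which sits on another core: the same change on two cores in this assay, a 2.9-fold lower number (0.47 log units; beyond the scatter) from compound 1 to compound 2 and a 6.9-fold higher number (0.84 log units; beyond the scatter) from compound 3 to compound 4, 20-fold (1.30 log units) apart, beyond the scatter of two such steps.

This shows that, in this series, the result of this change on the core of compound 1 does not carry over to the core of compound 3, in size or even in direction, so a step measured on one of these cores is a poor guide to the other. Going by these compounds alone, it does not show which difference between the two cores is responsible, since they differ in more than one place and each core offers only a single pair.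

From the compounds shown here alone, whether the reversal goes with the hydroxy group, the chloro group or the other differences between the cores remains open. The compounds shown also carry only methylsulfanyl and its oxygen-carrying counterpart at this position, which leaves unknown how an amine, a carboxylic acid or a longer chain would behave there on either core.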